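Swapping the sulfonyl aryl group in a kinase-inhibitor series

The source may hold more compounds than are shown below. What is called first, only, known or untested is meant among the compounds shown, and "the series" means these compounds.

Compound 3, `Cn1c(=O)c(S(=O)(=O)c2ccc(F)cc2N)cc2cnc(Nc3ccc4[nH]ccc4c3)nc21`, stands second highest of three numbers in a functional assay on K562 cells (Homo sapiens) for inhibition, read by trypan blue exclusion, with a stated time of 72 h (a higher number here means a weaker inhibitor, a lower number a stronger inhibitor), where compound 3 gives 2000 nM. Its nearest neighbour is compound 2, `Cn1c(=O)c(S(=O)(=O)Nc2ccc(F)cc2)cc2cnc(Nc3ccc4[nH]ccc4c3)nc21`, which in this assay gives 5000 nM; the step of a 2.5-fold lower number from compound 2 to compound 3 (0.40 log units; beyond the scatter). Furthest off is compound 1, `Cn1c(=O)c(S(=O)(=O)c2ccc([N+](=O)[O-])cc2F)cc2cnc(Nc3ccc4[nH]ccc4c3)nc21`, which gives 200 nM, so that a 10-fold higher number from compound 1 to compound 3 (1.00 log units; beyond the scatter), and a 25-fold higher number from compound 1 to compound 2 (1.40 log units; beyond the scatter). Compound 4, `Cn1c(=O)c(S(=O)(=O)c2ccc(Br)cc2)cc2cnc(Nc3ccc4[nH]ccc4c3)nc21`, has not yet been measured. The change from compound 3 to compound 4 is 4-bromophenyl in place of 2-amino-4-fluorophenyl on a sulfonyl sulfur. Among the measured compounds shown here, no measured pair shows this exact swap, but the step from compound 1 to compound 3 shows that altering the substituents on the aryl group bound to the sulfonyl sulfur moves the number beyond the scatter, and compound 1, with a plain aryl sulfone, holds the lowest number. A modest move toward a lower number is therefore expected for compound 4, about a 2.5-fold lower number from compound 3 to compound 4 (0.40 log units; beyond the scatter). Compound 4 is estimated at 800 nM, within a range of 200 nM to 3000 nM.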

Compound 4, half-maximal inhibitory concentration: 5000 nM
Compound 4: the middle estimate sits 6.3-fold (0.80 log units) below what was measured, outside the stated range (above it).
By their numbers in this assay, from the lowest: compound 1; then compound 3; then compounds 2 and 4 (each within the scatter of the next).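

In this assay, the step to the 4-bromophenyl group is upward (a 2.5-fold higher number from compound 3 to compound 4 (0.40 log units; beyond the scatter)), so an aryl group set directly on the sulfonyl sulfur does not by itself keep the number low. The (4-fluorophenyl)amino group of compound 2 no longer stands apart either (no change at the digits printed from compound 2 to compound 4 (within the scatter)), and compound 1 remains well separated from the 4-bromophenyl compound (a 25-fold higher number from compound 1 to compound 4 (1.40 log units; beyond the scatter)), which points to the particular 2-fluoro-4-nitrophenyl group rather than to the direct aryl link alone. Nothing available explains why these groups fall in this order.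

The compounds shown do not separate the nitro group of compound 1 from its fluorine. They also leave open what a 4-nitrophenyl, a 4-chlorophenyl or a 4-carboxyphenyl group would give on the same sulfonyl sulfur.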